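The source may report more compounds than this note shows. Statements on the series, on what has been measured and on what is new or still open speak of the compounds shown alone.

Compound 3, with the structure `Cc1cc(=O)n(-c2ccccc2OC(F)(F)F)nc1C(=O)Nc1ccc(Oc2ncnc3sccc23)cc1`, gives 15500 nM in a functional assay on A549 cells (Homo sapiens) for cytotoxicity, read by MTT assay, with a stated time of 72 h (on this read-out higher numbers stand for weaker inhibition and lower numbers for stronger inhibition), and so stands at the highest number among the three measured compounds. Compound 1, `Cc1cc(=O)n(-c2ccccc2OC(F)(F)F)nc1C(=O)Nc1ccc(Oc2ncnc3ccsc23)cc1`, gives 10100 nM in this assay, and the step of a 1.5-fold higher number from compound 1 to compound 3 (0.19 log units; within the scatter) lies within the scatter. Compound 2, `Cc1ccc(-n2nc(C(=O)Nc3ccc(Oc4ncnc5ccsc45)c(F)c3)c(C)cc2=O)cc1`, gives 5890 nM in this assay, the furthest of the measured values from compound 3.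

Compound 4 is `Cc1cc(=O)n(-c2ccc(F)cc2)nc1C(=O)Nc1ccc(Oc2ncnc3sccc23)cc1`. It differs from compound 3 in one place: 4-fluorophenyl in place of 2-(trifluoromethoxy)phenyl on an aromatic nitrogen. Within the data shown here, no measured pair differs in exactly this way, so no step bears directly on the change. Among the measured compounds shown here, the one measured step, from compound 1 to compound 3, concerns the other end of the molecule and is within the scatter. Compound 2 carries a 4-methylphenyl on the same aromatic nitrogen and shows the lowest of the three numbers, but it also differs from compound 1 in a fluorine on the central ring, so its two values only hint that a group of this kind on that nitrogen may go with a lower number.

Given this, compound 4 is expected to show a modest step of a 1.9-fold lower number from compound 3 to compound 4 (0.29 log units; within the scatter) toward a lower number, possibly within the scatter. The estimate for compound 4 in this assay is 8000 nM, with a range from 3000 nM to 25000 nM.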

Compound 4, half-maximal inhibitory concentration: 7050 nM
Estimate against measurement, compound 4: 1.1-fold (0.05 log units) above; the measured number falls inside the stated range.
By their numbers in this assay, from the lowest: compounds 2, 4, 1 and 3 (each within the scatter of the next, the first and the last beyond it).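

In this assay, among these compounds, the step of a 2.2-fold lower number from compound 3 to compound 4 (0.34 log units; beyond the scatter) is the first change at this aromatic nitrogen that can be read with everything else in the molecule held fixed, and it shows that the group on this nitrogen can move the number beyond the scatter, whereas the one earlier step, at the other end of the molecule, stayed within it. The step is modest, and it comes with a replacement of 2-(trifluoromethoxy)phenyl by the smaller 4-fluorophenyl, so the position tolerates this exchange without any rise in the number. Nothing available explains why the number falls with this change.

Among the compounds shown here, the single step cannot separate the loss of the trifluoromethoxy group from the gain of the fluorine, and an unsubstituted phenyl on this nitrogen, or a phenyl bearing an amine or a carboxylic acid, would speak to that question. From the compounds shown here alone, it also remains open whether the same exchange would give a similar step on the core of compound 1.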